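The source may report more compounds than this note shows. Statements on the series, on what has been measured and on what is new or still open speak of the compounds shown alone.

Measured in a functional assay on LoVo cells (Homo sapiens) for inhibition, read by MTT assay, with a stated time of 24 h; a higher number here means a weaker inhibitor, a lower number a stronger inhibitor:
- compound 1 `CC1(C)[C@H]2CC[C@]1(C)N(Cc1cn(-c3ccccc3C#N)nn1)C(=O)C2`: 140 nM
- compound 2 `CC1(C)[C@H]2CC[C@]1(C)N(Cc1cn(-c3ccc(F)cc3)nn1)C(=O)C2`: 40 nM
- compound 3 `CC1(C)[C@H]2CC[C@]1(C)N(Cc1cn(-c3ccccc3Cl)nn1)C(=O)C2`: 190 nM

Compound 3 shares the weak end of this small set with compound 1. The step between those two is a 1.4-fold higher number from compound 1 to compound 3 (0.13 log units; within the scatter), so they cannot be told apart. The other step that places it is a 4.8-fold higher number from compound 2 to compound 3 (0.68 log units; beyond the scatter), a real gap.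

Compound 4 `CC1(C)[C@H]2CC[C@]1(C)N(Cc1cn(-c3cccc(Cl)c3)nn1)C(=O)C2` has not yet been measured. It has the same atoms as compound 3, but the chlorine sits elsewhere on the phenyl ring: 3-chlorophenyl in place of 2-chlorophenyl on an aromatic nitrogen. For the measured compounds named here, no measured pair makes this exact move, so the evidence is indirect. Going by the values given here, the 2-cyanophenyl and 2-chlorophenyl compounds give similar numbers, while the one compound without a 2-substituted phenyl, carrying 4-fluorophenyl, gives a lower number. That change appears as a 3.5-fold lower number from compound 1 to compound 2 (0.54 log units; beyond the scatter). However, it also changes the substituent itself, and compound 4 keeps its chlorine, so only part of that gain is expected here. The expected step is a 1.9-fold lower number from compound 3 to compound 4 (0.28 log units; within the scatter), a small move toward a lower number. For compound 4 the estimated value is 100 nM, with an expected range from 35 nM to 280 nM.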

Compound 4, half-maximal inhibitory concentration: 70 nM
Compound 4: middle estimate off by 1.4-fold (0.15 log units), on the high side, within the range that was stated.
By their numbers in this assay, from the lowest: compounds 2, 4, 1 and 3 (each within the scatter of the next, the first and the last beyond it).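

In this assay, for the compounds shown here, compound 3 and compound 4 have the same atoms and differ only in the place of the chlorine on the phenyl ring, and that change alone gives a 2.7-fold lower number from compound 3 to compound 4 (0.43 log units; beyond the scatter); the earlier steps all changed the substituent itself, so they could not show that its place on the ring matters by itself. The other two new steps, a 1.8-fold higher number from compound 2 to compound 4 (0.24 log units; within the scatter) and a 2.0-fold lower number from compound 1 to compound 4 (0.30 log units; within the scatter), are too small to separate those pairs, so the 3-chlorophenyl group cannot be told apart from either the 4-fluorophenyl or the 2-cyanophenyl group in this read-out. Nothing given here explains why the place of the chlorine makes a difference.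

The compounds shown leave open whether 4-chlorophenyl would give a number closer to that of 3-chlorophenyl or a different one, and whether fluorine would show the same dependence on its place as 2-fluorophenyl or 3-fluorophenyl. They also leave open how this position would respond to a phenyl ring carrying an amine or a carboxylic acid in place of the halogen.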